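The source may report more compounds than this note shows. Statements on the series, on what has been measured and on what is new or still open speak of the compounds shown alone.

Working notes on the series. Among the measured compounds shown here, in a functional assay on DU-145 cells (Homo sapiens) for inhibition, read by MTT assay, with stated times of 18 h and 4 h (on this read-out lower numbers stand for stronger inhibition and higher numbers for weaker inhibition), compound 2 `CCCCCCOP(=O)(O)OCCSC(=S)N1CCCCCC1` gives 77400 nM, the only true number so far. For the measured compounds named here, compound 1 `CCCCCCCCOP(=O)(O)OCCSC(=S)N1CCN(C)CC1` reads > 100000 nM, which is a limit of the assay and not a number; the limit of > 100000 nM in this assay, at which 1 of the 2 values shown sits, is the only other reading available. Compound 3 `CCCCCCOP(=O)(O)OCCSC(=S)N1CCN(C)CC1` is unmeasured and carries 4-methylpiperazin-1-yl in place of azepan-1-yl on a thiocarbonyl carbon. Going by the values given here, no step between measured compounds is available to size this change. Among the compounds with values here, the only guide is compound 1, which also carries 4-methylpiperazin-1-yl and whose reading of > 100000 nM is a limit. The expected step, a 1.7-fold higher number from compound 2 to compound 3 (0.23 log units; within the scatter), is small, toward weaker inhibition, and may not exceed the usual scatter. A limit reading in this assay is thought more likely than not. For compound 3 the estimate is 130000 nM, with an expected range of 60000 nM to 280000 nM.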

Compound 3, half-maximal inhibitory concentration: > 100000 nM
Compound 3: no number, only a limit; the forecaster's own chance of this, stated with the estimate: 60%; the middle value is on the limit's open side.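

In this assay, 4-methylpiperazin-1-yl in place of azepan-1-yl on a thiocarbonyl carbon gives an at least 1.2-fold higher number from compound 2 to compound 3 (0.11 log units; that floor lies within the scatter), and this floor is all that can be said of the change. It gives no loss of inhibition beyond the scatter, so this position has no sized effect yet. Compound 3 reads as a limit and not a number, and with it both compounds that carry 4-methylpiperazin-1-yl now stand at the same limit, so the step between compound 1 and compound 3 cannot be read: the limit of > 100000 nM in this assay, at which 2 of the 3 values shown sit.

As far as these compounds go, how far compound 3 truly lies from compound 2 stays open, as does the effect of chain length when 4-methylpiperazin-1-yl is held fixed. Also open, from the compounds shown here alone, is whether another group on the thiocarbonyl carbon, such as morpholin-4-yl or diethylamino, would give stronger inhibition than azepan-1-yl.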